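Nitro in Place of Cyano: Expected Effect on Aromatase Inhibition

This account rests on a few compounds, and the source may have more. Where it says the series, first, only, none or still open, it means among the compounds named here.

Compound 1, `N#Cc1ccc2[nH]c(-c3ccccc3)cc2c1`, gives 82.3%
Compound 2, `c1ccc(Cn2c(-c3ccccc3)cc3ccccc32)cc1`, gives 0%
Compound 3, `Nc1ccccc1C#Cc1cc(F)cc(F)c1`, gives 9.27%

These three values come from an assay on isolated protein for inhibition of Aromatase (Homo sapiens), read by fluorescence, using NADPH, with a stated time of 30 min, tested at 50 uM; a higher number here means more inhibition at the concentration tested (going by the name of the read-out), a lower number less inhibition. Compound 1 stands highest of the three numbers. Its nearest neighbour is compound 3, whose value lies below it by a gap beyond the scatter, and compound 2 lies furthest, also beyond the scatter. Among the measured compounds shown here, no two of the measured compounds differ in a single place, so no step between measured compounds can be stated; the values show only that compound 1 has the highest number of the three in this assay, with the numbers of compound 2 and compound 3 both far below it.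

Compound 4, `O=[N+]([O-])c1ccc2[nH]c(-c3ccccc3)cc2c1`, has not yet been measured. It differs from compound 1 as follows: nitro in place of cyano on an aromatic carbon.

For the measured compounds named here, since no measured pair shows what such a change does in this assay, the expectation rests on compound 1 alone. The change swaps one small group for another on the same aromatic carbon, so a modest step is expected, most likely downward, but a value within the scatter of compound 1 would not surprise. Because compound 1 gives 82.3%, compound 4 is estimated at 70%, with a range from 45% to 90%, a step from compound 1 to compound 4 expected at a number 12.3 percentage points lower from compound 1 to compound 4 (beyond the scatter).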

Compound 4, a percentage reported as inhibition, at one concentration (the size of the read-out at that concentration, not a potency): 77.7%
Compound 4: middle estimate off by 7.7 percentage points, on the low side, and the stated range covers the measured number.
By their numbers in this assay, from the lowest: compounds 2 and 3 (each within the scatter of the next); then compounds 4 and 1 (each within the scatter of the next).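

Nitro in place of cyano on this aromatic carbon, on a six-membered aromatic ring of carbon only, gives a number 4.6 percentage points lower from compound 1 to compound 4 (within the scatter) in this assay, and this is the first single change that can be read among the compounds shown. At this position, then, the assay does not tell cyano, with 2 heavy atoms and 1 hydrogen-bond acceptor, from nitro, with 3 heavy atoms and 2 hydrogen-bond acceptors, so the high number seen for compound 1 is not tied to cyano alone. No measurement is at hand that would explain this result.

As far as these compounds go, what an amine, a carboxylic acid or a methoxy group would give on this same aromatic carbon stays open, as does the number for the core with only hydrogen there, which would show whether either group contributes at all. From the compounds shown here alone, since the read-out is a percentage at one concentration and not a potency, it also remains open whether compound 1 and compound 4 would still match at lower concentrations.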